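Swapping 4-nitrophenyl for 2-chlorophenyl: what number to expect

A few compounds are considered here, and "the series" means these few. Any claim that something is new, unique, unknown or untested is made for them only; others in the source may bear on it.

Values measured in a functional assay on NRK-49F cells (Rattus norvegicus) for cytotoxicity, read by MTT assay, with a stated time of 24 h (a lower number here means a stronger inhibitor, a higher number a weaker inhibitor), are these:

Compound 1 `COc1ccc(/C=C(\C#N)C(=O)N/N=C(\C)c2c(O)c3ccc(O)cc3oc2=O)cc1` gives 96100 nM
Compound 2 `C/C(=N\NC(=O)/C(C#N)=C/c1ccc([N+](=O)[O-])cc1)c1c(O)c2ccc(O)cc2oc1=O` gives 43200 nM

Of the two, compound 2 holds the lowest number, which makes it the stronger inhibitor of this pair. The next compound, compound 3 `C/C(=N\NC(=O)/C(C#N)=C/c1ccccc1Cl)c1c(O)c2ccc(O)cc2oc1=O`, has not yet been measured. Its change from compound 2 is 2-chlorophenyl in place of 4-nitrophenyl on a double-bonded chain carbon bound to a double-bonded chain carbon.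

Among the measured compounds shown here, only one measured step bears on this change. It is a 2.2-fold lower number from compound 1 to compound 2 (0.35 log units; beyond the scatter), with nitro in place of methoxy on an aromatic carbon. For the measured compounds named here, that step is modest, and no compound carrying chlorine has been measured, so the guidance is thin. Compound 3 gives up the nitro group, so it may lose part of that gain, and it is expected to move a little towards a higher number (a 1.4-fold higher number from compound 2 to compound 3 (0.16 log units; within the scatter)). The estimate for compound 3 is 62000 nM (expected range 25000 nM to 130000 nM).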

Compound 3, half-maximal inhibitory concentration: 55900 nM
For compound 3 the middle estimate is 1.1-fold (0.04 log units) above the measured one; the range from low to high includes it.
By their numbers in this assay, from the lowest: compounds 2, 3 and 1 (each within the scatter of the next, the first and the last beyond it).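

Compound 3 brings the first ring at this place that carries neither nitro nor methoxy, and in this assay the change from 4-nitrophenyl to 2-chlorophenyl gives a 1.3-fold higher number from compound 2 to compound 3 (0.11 log units; within the scatter) even though the group entering has 7 heavy atoms and 0 hydrogen-bond acceptors, against 9 heavy atoms and 2 hydrogen-bond acceptors in the group leaving. The change from 4-methoxyphenyl to 2-chlorophenyl gives a 1.7-fold lower number from compound 1 to compound 3 (0.24 log units; within the scatter) as well, so compound 3 cannot be told apart from either neighbour, although those two neighbours do differ from each other beyond the scatter. Among the compounds shown here, the nitro group is therefore not required for a number in this range, and the one step seen earlier now looks like a small spread among three close compounds rather than a clear gain tied to nitro, though no measurement here explains why these groups give such close numbers.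

From the compounds shown here alone, with the substituent and its location on the ring both changing from compound 2 to compound 3, the effect of each alone stays unknown, and a plain phenyl or a 4-chlorophenyl would separate the two. Going by these compounds, whether a ring bearing an amine or a carboxylic acid, or a longer chain in place of the ring, would shift the number well beyond this narrow band also stays open.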